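Removing One Methoxy From a Benzothiophene Stilbene

The source may report more compounds than this note shows. Statements on the series, on what has been measured and on what is new or still open speak of the compounds shown alone.

Compound 1 `COc1ccc2sc(/C=C\c3cc(OC)c(OC)c(OC)c3)cc2c1` pairs a trimethoxyphenyl ring with a fused bicyclic core through a cis double bond, and the core carries a methoxy group. In a functional assay on RL cells (Homo sapiens) for antiproliferative activity, read by MTT assay, with a stated time of 72 h (on this read-out higher numbers stand for weaker inhibition and lower numbers for stronger inhibition), compound 1 has no single number: its result is "not determined" (no result reported). Compound 2 `COc1ccsc1/C=C\c1cc(OC)c(OC)c(OC)c1` carries a smaller sulfur ring with a methoxy group. In this assay compound 2 reaches only a limit, > 1000 nM, which is a boundary of the measurement rather than a number. That limit, (the limit of > 1000 nM in this assay, at which 1 of the 3 values shown sits), is the only reported result among the three measured entries. Compound 3 `COc1ccc(/C=C\c2cc(OC)c(OC)c(OC)c2)s1`, with a methoxy on another position of a small sulfur ring, likewise has no single number in this assay: its result is "not determined" (no result reported).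

Compound 4 `COc1cc(/C=C\c2cc3ccccc3s2)cc(OC)c1OC` is the unmeasured partner of compound 1. The change is hydrogen in place of methoxy on an aromatic carbon. The fused core and the cis linkage to the trimethoxyphenyl ring stay as they are.

No measured step connects any two of these compounds, so the size of this change in this assay cannot be anchored; the expectation is a modest step, within the scatter, in either direction. For compound 4 the expected value in this assay is 500 nM, with a range from 50 nM to 5000 nM.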

Compound 4, half-maximal inhibitory concentration: 7.6 nM
Compound 4: the middle estimate sits 66-fold (1.82 log units) above what was measured; the measured number lies below the stated range.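

Among these compounds, compound 4 has a value in this assay, but compound 1 has no single number there, and no step between the two can be read. As far as these compounds go, what removing the methoxy group from compound 1 does to this activity stays open. Nothing shown here accounts for the result of compound 4.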